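Changing the Group on the Nitrogen of Compound 3

A few compounds are considered here, and "the series" means these few. Any claim that something is new, unique, unknown or untested is made for them only; others in the source may bear on it.

In a functional assay on FaDu cells (Homo sapiens) for cytotoxicity, read by MTT assay, with a stated time of 72 h (a higher number here means that more compound is tolerated, a lower number that less compound is tolerated), compound 1 `COc1ccc(NC(=O)C(=O)c2cn(C(C)C)c3ccccc23)cn1` stands at 85 nM and compound 2 `CCC(C)n1cc(C(=O)C(=O)Nc2ccc(OC)nc2)c2ccccc21` at 68 nM and the move between them is a 1.3-fold lower number from compound 1 to compound 2 (0.10 log units; within the scatter) and so tells little. Compound 3 `COc1ccc(NC(=O)C(=O)c2cn(C3CCCC3)c3ccccc23)cn1` at 370 nM has the highest of the three numbers. Compound 4 `COc1ccc(NC(=O)C(=O)c2cn(CC3CCCO3)c3ccccc23)cn1` carries (oxolan-2-yl)methyl in place of cyclopentyl on an aromatic nitrogen. Two measured steps changed the group on this nitrogen, a 4.4-fold higher number from compound 1 to compound 3 (0.64 log units; beyond the scatter) and a 5.4-fold higher number from compound 2 to compound 3 (0.74 log units; beyond the scatter) and both are modest. Neither brings in a ring with a hetero atom, so they guide only the size. A step no larger than these is expected, leaning towards a lower number (a 1.9-fold lower number from compound 3 to compound 4 (0.27 log units; within the scatter)). For compound 4 the estimated value is 200 nM (expected range 60 nM to 650 nM).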

Compound 4, concentration lethal to 50% of the cells: 31 nM
Beside the measured number, compound 4's estimate is 6.5-fold (0.81 log units) above it; measured number below the stated range.
By their numbers in this assay, from the lowest: compound 4; then compounds 2 and 1 (each within the scatter of the next); then compound 3.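

Among the compounds shown here, on this aromatic nitrogen, (oxolan-2-yl)methyl gives the lowest number so far in this assay, with a 12-fold lower number from compound 3 to compound 4 (1.08 log units; beyond the scatter) and smaller steps against the open-chain groups (a 2.2-fold lower number from compound 2 to compound 4 (0.34 log units; beyond the scatter) and a 2.7-fold lower number from compound 1 to compound 4 (0.44 log units; beyond the scatter)). Compound 3 and compound 4 both carry a five-membered non-aromatic ring, so having such a ring at this position does not alone set the number. No measurement available here explains the drop.

On these data alone, it remains open whether the ring oxygen or the methyl link matters more. Cyclopentylmethyl on this nitrogen would separate the two.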